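The compounds below may be only part of what the source reports. "The series", "measured", "known", "first", "only" and "open" are said of these compounds alone.

Series notes, oral rat exposure.

Compound 1 `CC(C)(C)CCC1(NCc2ccc3ccccc3c2)C(=O)C(C2=NS(=O)(=O)c3cc(NS(C)(=O)=O)ccc3N2)=C(O)c2ccccc21` carries naphthalen-2-yl on a saturated chain carbon bound to an amine nitrogen. In an in vivo ADME assay on the whole organism (strain Sprague-Dawley) for pharmacokinetics, with Rattus norvegicus as the target, at a dose of 5 mg/kg by the oral route (on this read-out higher numbers stand for higher exposure at the dose given and lower numbers for lower exposure), compound 1 gives 268 nM. Compound 2 `Cc1cccc(C)c1CNC1(CCC(C)(C)C)C(=O)C(C2=NS(=O)(=O)c3cc(NS(C)(=O)=O)ccc3N2)=C(O)c2ccccc21` replaces that group with 2,6-dimethylphenyl, and in this assay compound 2 gives 707 nM; the change reads a 2.6-fold higher number from compound 1 to compound 2 (0.42 log units; beyond the scatter). On the two numbers in hand compound 2 stands highest, with compound 1 the nearest and lower.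

Compound 3 `Cc1cccc(CNC2(CCC(C)(C)C)C(=O)C(C3=NS(=O)(=O)c4cc(NS(C)(=O)=O)ccc4N3)=C(O)c3ccccc32)n1` is not yet measured. Its difference from compound 2 is 6-methylpyridin-2-yl in place of 2,6-dimethylphenyl on a saturated chain carbon bound to an amine nitrogen. Among the measured compounds shown here, the only measured step sits at this same chain carbon, a 2.6-fold higher number from compound 1 to compound 2 (0.42 log units; beyond the scatter), but it swaps one carbon-only aromatic group for another, so it tells little about bringing in a ring nitrogen. With a single step of that kind available and a change of a different sort here, no direction can be read from the data; the expectation is a step within the scatter, a 1.4-fold lower number from compound 2 to compound 3 (0.15 log units; within the scatter). On that basis compound 3 is estimated at 500 nM in this assay, with a range of 150 nM to 1600 nM.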

Compound 3, maximal plasma concentration: 235 nM
For compound 3 the middle estimate is 2.1-fold (0.33 log units) above the measured one; the range from low to high includes it.
By their numbers in this assay, from the lowest: compounds 3 and 1 (each within the scatter of the next); then compound 2.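

In this assay, among the compounds shown here, the change at this chain carbon does not hold the level reached with 2,6-dimethylphenyl: 6-methylpyridin-2-yl gives a 3.0-fold lower number from compound 2 to compound 3 (0.48 log units; beyond the scatter) and so shows that this position can also move the number down, which the single earlier step did not show. Against naphthalen-2-yl the same group gives a 1.1-fold lower number from compound 1 to compound 3 (0.06 log units; within the scatter) and places compound 3 within the scatter of compound 1, so among these three aromatic groups only the 2,6-dimethylphenyl of compound 2 stands apart, even though the groups of compound 1 and compound 3 are quite unlike each other. Nothing in hand bears on the reason for these differences.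

The step to compound 3 changes a ring carbon to a ring nitrogen and also removes a methyl, so the compounds shown cannot separate the two; a 2-methylphenyl group or a 2,6-dimethylpyridin-3-yl group on the same chain carbon would bear on that. As far as these compounds go, it also remains open whether the gap between compound 2 and the other two carries over from maximal concentration to total exposure over time.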